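A few compounds are considered here, and "the series" means these few. Any claim that something is new, unique, unknown or untested is made for them only; others in the source may bear on it.

Compound 1 `Nc1ccc(S(=O)(=O)N2CCN(c3ncc(C(O)(C(F)(F)F)C(F)(F)F)cc3C#CCO)CC2)cn1`: < 14 mL.min-1.g-1 (a limit)
Compound 2 `Nc1ccc(S(=O)(=O)N2CCN(c3ncc(C(O)(C(F)(F)F)C(F)(F)F)cc3-c3ccncc3)CC2)cn1`: 15 mL.min-1.g-1
Compound 3 `Nc1ccc(S(=O)(=O)N2CCN(c3ncc(C(O)(C(F)(F)F)C(F)(F)F)cc3-c3ccc4c(c3)CC(=O)N4)CC2)cn1`: < 14 mL.min-1.g-1 (a limit)

All three compounds were tested in an ADME assay (liver) for metabolic stability, with Liver microsome (Homo sapiens) as the target, using microsomes and NADPH, with a stated time of 30 min, tested at 1 uM; on this read-out higher numbers stand for fast clearance and lower numbers for slow clearance. For compound 3 the assay reports only a limit, < 14 mL.min-1.g-1. This is the limit of < 14 mL.min-1.g-1 in this assay, at which 2 of the 3 values shown sit.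

Compound 4 `Nc1ccc(S(=O)(=O)N2CCN(c3ncc(C(O)(C(F)(F)F)C(F)(F)F)cc3-c3cc4ccccc4[nH]3)CC2)cn1` differs from compound 3 in one place: a group of 9 heavy atoms (8 carbon, 1 nitrogen; one five-membered aromatic ring with 1 hetero atom, one six-membered aromatic ring of carbon only) in place of a group of 10 heavy atoms (8 carbon, 1 nitrogen, 1 oxygen; one five-membered non-aromatic ring with 1 hetero atom, one six-membered aromatic ring of carbon only), on an aromatic carbon. 1H-indol-2-yl enters on an aromatic carbon of a six-membered aromatic ring with 1 nitrogen.

Three measured steps change the group at this place. The first is an at least 1.0-fold higher number from compound 1 to compound 2 (0.02 log units; that floor lies within the scatter), and the second is an at least 1.0-fold lower number from compound 2 to compound 3 (0.02 log units; that floor lies within the scatter). The third is a step that the two limits leave unreadable from compound 1 to compound 3. None shows a change beyond the scatter, though the limits hide how large these steps really are. Among the measured compounds shown here, no measured compound carries 1H-indol-2-yl, so the expectation stays loose. Compound 2 gives a real number, 15 mL.min-1.g-1, and a similar number is expected here. The expected change is small and upward, an at least 1.2-fold higher number from compound 3 to compound 4 (0.10 log units; that floor lies within the scatter). Compound 4 is estimated at 18 mL.min-1.g-1, with an expected range from 11 mL.min-1.g-1 to 40 mL.min-1.g-1.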

Compound 4, intrinsic clearance in microsomes: < 14 mL.min-1.g-1
Compound 4: no number, only a limit; the forecaster's own chance of this, stated with the estimate: 40%; middle value at least 1.2-fold (0.10 log units) from the limit.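

Among the compounds shown here, compound 4 also gives only a limit, and with it a fused aromatic group, 1H-indol-2-yl, joins the 3-hydroxyprop-1-yn-1-yl of compound 1 and the group of compound 3 at the same limit, while the pyridin-4-yl of compound 2 remains the only group here with a real number. Replacing pyridin-4-yl with 1H-indol-2-yl gives an at least 1.0-fold lower number from compound 2 to compound 4 (0.02 log units; that floor lies within the scatter), so this change cannot be told apart from the scatter, and the steps from compound 1 and compound 3 to compound 4 cannot be read. The position now shows mostly one reading in this assay: the limit of < 14 mL.min-1.g-1 in this assay, at which 3 of the 4 values shown sit.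

On these data alone, how far compound 1, compound 3 and compound 4 truly lie under the limit stays open, so they cannot be ranked. As far as these compounds go, it is also open whether an aminomethyl group or a carboxylic acid at this place would give a readable number.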